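This account rests on a few compounds, and the source may have more. Where it says the series, first, only, none or still open, it means among the compounds named here.

Measured so far in an ADME assay on microsomes from liver (Mus musculus) for metabolic stability, read by LC-MS, with a stated time of 10 min, tested at 0.5 uM; a lower number here means that less of the compound is left, a higher number that more of the compound is left:
compound 1 `c1ccc2c(c1)CN[C@@H](CN(CC[C@@H]1CCCNC1)[C@H]1CCCc3cccnc31)C2` gives 23%;
compound 2 `c1cnc2c(c1)CCC[C@@H]2N(CCCN1CCNCC1)Cc1cc2ccccc2cn1` gives 74%;
compound 3 `c1cnc2c(c1)CN[C@@H](CN(CCCN1CCNCC1)[C@H]1CCCc3cccnc31)C2` gives 78%.

Compound 1 stands lowest of the three, with compound 2 and compound 3 both well beyond the scatter above it. Among the measured compounds shown here, the only single-point step measured is a number 4 percentage points higher from compound 2 to compound 3 (within the scatter), which touches a different part of the molecule and does not bear on the change at hand. Compound 4 `CN1CCN(CCCN(C[C@H]2Cc3ccccc3CN2)[C@H]2CCCc3cccnc32)CC1` differs from compound 1 by (4-methylpiperazin-1-yl)methyl in place of piperidin-3-yl on a saturated chain carbon, two bonds along the chain from an amine nitrogen. For the measured compounds named here, no measured pair isolates this change; compound 1 and compound 3 differ in more than one place, so their values only hint that the propyl-linked cyclic diamine chain sits with the higher numbers. The estimate for compound 4 is therefore a rise, a number 22 percentage points higher from compound 1 to compound 4 (beyond the scatter), to about 45% with a range from 20% to 75%.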

Compound 4, percent of the compound remaining: 53%
Beside the measured number, compound 4's estimate is 8 percentage points below it, and the stated range covers the measured number.
By their numbers in this assay, from the lowest: compound 1; then compound 4; then compounds 2 and 3 (each within the scatter of the next).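

In this assay, among the compounds shown here, this is the only direct single-place reading at this position: a number 30 percentage points higher from compound 1 to compound 4 (beyond the scatter), with (4-methylpiperazin-1-yl)methyl in place of piperidin-3-yl on a saturated chain carbon, two bonds along the chain from an amine nitrogen. It shows that the group at this place can shift how much compound is left on the core of compound 1. Nothing at hand explains the rise. Going by these compounds, the swap alters the ring, the chain and the methyl together, so which part matters stays open, as does how a morpholine ring or a longer chain would fare there.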